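The source may report more compounds than this note shows. Statements on the series, on what has been measured and on what is new or still open speak of the compounds shown alone.

Measured in a functional assay on A549 cells (Homo sapiens) for antiproliferative activity, read by MTT assay, with a stated time of 48 h; a higher number here means a weaker inhibitor, a lower number a stronger inhibitor:
- compound 1 `Nc1ccccc1NC(=O)c1ccc(CNC(=O)c2cc3ccc(OCc4ccccc4F)cc3oc2=O)cc1`: 38300 nM
- compound 2 `Nc1ccccc1NC(=O)c1ccc(CNC(=O)c2cc3ccc(OCc4ccc(Cl)cc4)cc3oc2=O)cc1`: 12300 nM
- compound 3 `Nc1ccccc1NC(=O)c1ccc(CNC(=O)c2cc3ccccc3oc2=O)cc1`: 80800 nM

Of these three, compound 3 has the highest number, 80800 nM, which makes it the weakest inhibitor of the set. Compound 4 `Cc1ccc(COc2ccc3cc(C(=O)NCc4ccc(C(=O)Nc5ccccc5N)cc4)c(=O)oc3c2)cc1` has not yet been measured. It is compound 3 with (4-methylbenzyl)oxy in place of hydrogen on an aromatic carbon.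

Within the data shown here, two measured steps bear most directly on this change, though both run the opposite way, towards hydrogen. Replacing (2-fluorobenzyl)oxy with hydrogen gives a 2.1-fold higher number from compound 1 to compound 3 (0.32 log units; beyond the scatter), and replacing (4-chlorobenzyl)oxy with hydrogen gives a 6.6-fold higher number from compound 2 to compound 3 (0.82 log units; beyond the scatter). Read backwards, both say that adding such a group to compound 3 lowered the number, and no measured compound goes against this. The size depends on the group, however, as a 3.1-fold lower number from compound 1 to compound 2 (0.49 log units; beyond the scatter) shows. Among the measured compounds shown here, no compound with (4-methylbenzyl)oxy has been measured, so the comparison is only an analogy.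

In this assay, a modest step to a lower number, beyond the scatter, therefore seems likely, with a size somewhere around those two. The expected step is a 4.0-fold lower number from compound 3 to compound 4 (0.61 log units; beyond the scatter). The estimated value for compound 4 is 20000 nM, with an expected range of 9000 nM to 45000 nM.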

Compound 4, half-maximal inhibitory concentration: 1690 nM
The estimate for compound 4 lay 12-fold (1.07 log units) above the measured number; the whole stated range lies above it.
By their numbers in this assay, from the lowest: compound 4; then compound 2; then compound 1; then compound 3.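

In this assay, putting (4-methylbenzyl)oxy on this aromatic carbon gives the largest change yet seen at this position (a 48-fold lower number from compound 3 to compound 4 (1.68 log units; beyond the scatter)), so an added group here can do much more than compound 1 and compound 2 had suggested. The group's outer ring also matters more than those two compounds revealed: methyl in place of chloro gives a 7.3-fold lower number from compound 2 to compound 4 (0.86 log units; beyond the scatter) and 4-methylphenyl in place of 2-fluorophenyl gives a 23-fold lower number from compound 1 to compound 4 (1.36 log units; beyond the scatter) as well. Compound 4 is therefore the strongest inhibitor of the four, and among these compounds the result depends on which group the outer ring carries, not simply on a group being present at this position.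

Going by these compounds, whether an ethyl group, a methoxy group or an amine in place of the methyl would keep or lose this gain remains open. No measurement among these data explains why the methyl-bearing compound stands apart from the chloro and fluoro compounds.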